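The source may hold more compounds than are shown below. What is called first, only, known or untested is meant among the compounds shown, and "the series" means these compounds.

Compound 1 `Cc1cn(C[C@H]2CN(c3ccc(C4=CCS(=O)(=O)CC4)c(F)c3)C(=O)O2)nn1` gives 25000 nM in an assay for binding affinity to Amine oxidase [flavin-containing] A (Homo sapiens); on this read-out lower numbers stand for stronger inhibition and higher numbers for weaker inhibition.
Compound 2 `O=C1O[C@@H](Cn2cc(Cl)nn2)CN1c1ccc(C2=CCS(=O)(=O)CC2)c(F)c1` gives 3000 nM in this assay.

Among the measured compounds shown here, of the two numbers measured in this assay, compound 1 has the highest, which on this read-out means the weakest binding of the pair; the only neighbour, compound 2, is reached by an 8.3-fold lower number from compound 1 to compound 2 (0.92 log units; beyond the scatter). The compound now in question is compound 3 `O=C1O[C@@H](Cn2cc(Br)nn2)CN1c1ccc(C2=CCS(=O)(=O)CC2)c(F)c1`, and what separates it from compound 1 is bromo in place of methyl on an aromatic carbon. For the measured compounds named here, only one measured step speaks to this change: the exchange of the same methyl for chloro at the same carbon of the triazole, which gave an 8.3-fold lower number from compound 1 to compound 2 (0.92 log units; beyond the scatter). Bromo and chloro are both halogens of comparable kind at this position, and nothing among the measured compounds distinguishes the two, so a step of similar size and in the same direction, toward a lower number, is the most reasonable expectation. Compound 3 is therefore estimated at 2500 nM, with a plausible range from 700 nM to 8000 nM, which would amount to a 10-fold lower number from compound 1 to compound 3 (1.00 log units; beyond the scatter).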

Compound 3, inhibition constant: 16000 nM
Beside the measured number, compound 3's estimate is 6.4-fold (0.81 log units) below it, outside the stated range (above it).
By their numbers in this assay, from the lowest: compound 2; then compounds 3 and 1 (each within the scatter of the next).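

Bromo in place of methyl gives a 1.6-fold lower number from compound 1 to compound 3 (0.19 log units; within the scatter) in this assay, so on this read-out these two groups cannot be told apart at this carbon of the triazole. The lower number seen with chloro therefore does not extend to every halogen, and the direct exchange of one halogen for the other gives a 5.3-fold higher number from compound 2 to compound 3 (0.73 log units; beyond the scatter), a step beyond the scatter between two single atoms on the same aromatic carbon. With three compounds in hand, chloro stands apart from both methyl and bromo, and nothing available here accounts for the split between the two halogens.

Fluoro and iodo at the same carbon would show whether chloro is an isolated case or part of a wider series among the halogens, while a nitrile, a methoxy group or an amine would test groups of quite another kind. As far as these compounds go, it also remains open whether the step from chloro to bromo would keep its direction and size on a core other than the one shared by these three compounds.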